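Swapping a Methyl on a Carbonyl Carbon

The source may report more compounds than this note shows. Statements on the series, on what has been measured and on what is new or still open speak of the compounds shown alone.

Of the compounds shown here, three have so far been tested in a physicochemical assay for solubility, read by chemiluminescence, measured as kinetic solubility; a lower number here means a less soluble compound, a higher number a more soluble compound. Compound 1 `CC(=O)NCc1cccc(Cn2nc(NS(=O)(=O)c3ccc(Cl)s3)c3c(CO)cccc32)c1` reads >= 113 ug/mL, and that figure is a limit, not a number. Within the data shown here, compound 2 `COc1cccc2c1c(NS(=O)(=O)c1ccc(Cl)s1)nn2Cc1cccc(CNC2COC2)c1` gives 122 ug/mL, the only exact number among the three. Compound 3 `COc1c(F)ccc2c1c(NS(=O)(=O)c1ccc(Cl)s1)nn2Cc1cccc(CNC(C)=O)c1` reads >= 199 ug/mL, which is likewise a limit and not a number, and this is where the step begins.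

Compound 4 `COc1c(F)ccc2c1c(NS(=O)(=O)c1ccc(Cl)s1)nn2Cc1cccc(CNC(=O)C(C)(C)O)c1` differs from compound 3 in one place. On a carbonyl carbon whose other neighbour is an amide-type nitrogen, 1-hydroxy-1-methylethyl stands in place of methyl, (1-hydroxy-1-methylethyl in place of methyl on a carbonyl carbon), and the rest of the molecule stays the same. Read one bond further out, acetamido becomes ((1-hydroxy-1-methylethyl)carbonyl)amino.

Among the measured compounds shown here, no two measured compounds differ in one place only, so the data give no direct measure of a change like this one. Repeated measurements of a single compound also differ somewhat, so a small gap would mean little. The expectation rests on compound 3, whose limit of >= 199 ug/mL is the only starting point for this pair. The estimated step of an at least 1.1-fold lower number from compound 3 to compound 4 (0.04 log units; that floor lies within the scatter) is expected to stay within the usual scatter, in neither direction. For compound 4 in this assay the expected value is 180 ug/mL with a range from 90 ug/mL to 320 ug/mL as an estimate.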

Compound 4, solubility: >= 174 ug/mL
Compound 4 ended at the assay's limit (the forecaster's own chance of this, stated with the estimate: 45%); the middle value lies beyond the limit too.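

In this assay compound 3 gives >= 199 ug/mL, which is a limit and not a number. Compound 4 gives >= 174 ug/mL, which is also a limit. With only these two limits, the step between compound 3 and compound 4 cannot be read. As far as these compounds go, whether 1-hydroxy-1-methylethyl in place of methyl on a carbonyl carbon changes the solubility read-out at all, and by how much, stays open.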